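A few compounds are considered here, and "the series" means these few. Any claim that something is new, unique, unknown or untested is made for them only; others in the source may bear on it.

Measured in a physicochemical assay for solubility, read by HPLC, using the shake flask method, in phosphate buffer, with a stated time of 2 h, at pH 6.5; a lower number here means a less soluble compound, a higher number a more soluble compound:
compound 1 `Nc1ncc(-c2ccc(C(=O)N3CC[C@H](O)C3)cc2)nc1-c1ccc(C(F)(F)F)cc1` — 68000 nM
compound 2 `CNC(=O)c1ccc(-c2nc(-c3ccc(C(N)=O)cc3)cnc2N)cc1` — 178000 nM
compound 3 `Nc1ccc(-c2nc(-c3ccc(S(=O)(=O)C4CC4)cc3)cnc2N)cn1` — 13000 nM

Compound 1 holds the second highest of the three numbers in this assay. Within the data shown here, compound 2 stands higher and compound 3 lower, each by a gap beyond the usual scatter; neither of those compounds differs from compound 1 in a single place, so no step among the measured compounds is counted.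

Compound 4 `Nc1ncc(-c2ccc(C(=O)N3CC[C@@H](O)C3)cc2)nc1-c1ccc(C(F)(F)F)cc1` has not been measured. Against compound 1 it changes as follows: the two compounds have the same atoms and bonds and differ only in configuration as drawn: 1 of 1 stereo elements differ; a stereocentre at a saturated ring carbon is drawn S in compound 1 and R in compound 4. Among the measured compounds shown here, no measured pair in this set shows what such a change does in this assay. A change in drawn configuration alone, with the same atoms and bonds, gives no ground in these numbers to expect a move, so none beyond the scatter is expected in either direction. For compound 4 the estimate in this assay is 68000 nM, in the range 40000 nM to 115000 nM. The expected step from compound 1 to compound 4 is no change at the digits printed from compound 1 to compound 4 (within the scatter), within the scatter.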

Compound 4, solubility: 90000 nM
The estimate for compound 4 lay 1.3-fold (0.12 log units) below the measured number; measured number inside the range.
By their numbers in this assay, from the lowest: compound 3; then compounds 1, 4 and 2 (each within the scatter of the next, the first and the last beyond it).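

In this assay, changing the stereocentre at a saturated ring carbon from S to R gives a 1.3-fold higher number from compound 1 to compound 4 (0.12 log units; within the scatter). Among these compounds, this is the first single-place step, and at this stereocentre the drawn configuration does not separate the two compounds. The step can be tied to that stereocentre alone: the fact that compounds 1 and 4 differ only in the configuration as drawn

On these data alone, whether the two configurations stay this close with an amine or a carboxylic acid in place of the hydroxyl group remains open. Among the compounds shown here, the effect of replacing the trifluoromethyl group, for which no single-place step is available, is also open.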